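A few compounds are considered here, and "the series" means these few. Any claim that something is new, unique, unknown or untested is made for them only; others in the source may bear on it.

Measured compounds:
- compound 1, `Oc1cc(C(F)(F)F)ccc1-c1nc(-c2ccccc2O)n(-c2ccc(F)cc2)n1`, gives 67.2%
- compound 2, `Oc1cc(C(F)(F)F)ccc1-c1nc(-c2ccccc2O)n(-c2ccc(Cl)cc2)n1`, gives 68%
- compound 3, `Oc1cc(C(F)(F)F)ccc1-c1nc(-c2ccccc2O)n(-c2ccccc2F)n1`, gives 63.4%

All three were tested in a functional assay on PC-12 cells (Rattus norvegicus) for cytotoxicity, read by MTT assay, with stated times of 2 h and 24 h, tested at 1 uM; on this read-out lower numbers stand for a weaker effect and higher numbers for a stronger effect at the one concentration tested. The three numbers sit close together: the step of a number 0.8 percentage points higher from compound 1 to compound 2 (within the scatter), the step of a number 3.8 percentage points lower from compound 1 to compound 3 (within the scatter) and the step of a number 4.6 percentage points lower from compound 2 to compound 3 (within the scatter) all stay inside the usual scatter of this assay, so none of the three compounds can be called stronger or weaker than another.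

Compound 4, `Oc1cc(C(F)(F)F)ccc1-c1nc(-c2ccccc2O)n(-c2ccccc2Cl)n1`, has not yet been measured. It differs from compound 3 by chloro in place of fluoro on an aromatic carbon. The same kind of change has already been made once, from compound 1 to compound 2, where it reads chloro in place of fluoro on an aromatic carbon and gave a number 0.8 percentage points higher from compound 1 to compound 2 (within the scatter). The two places are not identical: in the measured pair the exchanged atom sits para to a large group, whereas in compound 4 it sits ortho to a large group. The cores of the two pairs differ by 2-fluorophenyl in place of 4-fluorophenyl on an aromatic nitrogen.

Because the measured step of a number 0.8 percentage points higher from compound 1 to compound 2 (within the scatter) was small, the step from compound 3 to compound 4 is expected to be small as well, about a number 0.6 percentage points higher from compound 3 to compound 4 (within the scatter). On that basis compound 4 is estimated to give about 64% in this assay, most likely between 54% and 74%.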

Compound 4, a percentage reported as activity, at one concentration (the size of the read-out at that concentration, not a potency): 70.1%
Beside the measured number, compound 4's estimate is 6.1 percentage points below it; low and high end bracket the measured number.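

In this assay, the step from 2-fluorophenyl to 2-chlorophenyl is a number 6.7 percentage points higher from compound 3 to compound 4 (within the scatter), and it cannot be told apart from the same exchange of fluoro for chloro on the other core: the same change on two cores in this assay, a number 0.8 percentage points higher (within the scatter) from compound 1 to compound 2 and a number 6.7 percentage points higher (within the scatter) from compound 3 to compound 4, 5.9 percentage points apart, within the scatter of two such steps. The other two new comparisons also stay inside the usual scatter, with a number 2.1 percentage points higher from compound 2 to compound 4 (within the scatter) and a number 2.9 percentage points higher from compound 1 to compound 4 (within the scatter), so all the compounds shown remain level with one another in this assay. Going by these compounds alone, this shows that, in these two pairs, exchanging fluoro for chloro gave no step that can be separated from the noise of repeated measurements, but it does not show that the change has no effect, that its true size is the same on both cores, or that it would behave the same way on any other core.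

The compounds shown carry only fluoro or chloro on the phenyl group attached to the aromatic nitrogen, so it remains open whether a different group there, such as methyl, methoxy, an amine or a carboxylic acid, would give a step beyond the scatter. On these data alone, it is also open how the numbers would respond if the trifluoromethyl group or either hydroxyl group of the shared core were replaced.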